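The source may report more compounds than this note shows. Statements on the series, on what has been measured and on what is new or still open speak of the compounds shown alone.

Measured in a functional assay on T47D cells (Homo sapiens) for inhibition, read by CCK-8 assay, with a stated time of 72 h, tested at 1 uM; on this read-out lower numbers stand for less inhibition of growth and higher numbers for more inhibition of growth at the one concentration tested:

- compound 1 `CN(C)C(=O)c1cc2cnc(Nc3ccc(NC(=O)C4(C(=O)Nc5cccc(O)c5)CC4)cc3)nc2n1C1CCCC1` gives 80.7%
- compound 2 `CN(C)C(=O)c1cc2cnc(Nc3ccc(NC(=O)C4(C(=O)Nc5ccccc5F)CC4)cc3)nc2n1C1CCCC1` gives 85.2%
- compound 3 `Nc1ccc(NC(=O)C2(C(=O)Nc3ccc(F)cc3)CC2)cc1F` gives 5.6%

Compound 2 cannot be separated from compound 1 on these numbers, since the two lie within the scatter of each other. Both lie far above compound 3, a much smaller molecule without the core of compound 1.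

The next compound to be tested is compound 4 `CN(C)C(=O)c1cc2cnc(Nc3ccc(NC(=O)C4(C(=O)Nc5cccc(Br)c5)CC4)cc3)nc2n1C1CCCC1`. It keeps the core of compound 2 and changes only the group on the amide-type nitrogen, with 3-bromophenyl in place of 2-fluorophenyl on an amide-type nitrogen.

Among the measured compounds shown here, one measured step bears on this change. Compound 1 and compound 2 differ at this same place, and a number 4.5 percentage points higher from compound 1 to compound 2 (within the scatter) is small. For the measured compounds named here, that single step is thin evidence, and no measured compound carries a bromine. Even so, it gives no reason to expect a large change in this assay, and no clear direction either. The estimated a number 4.2 percentage points lower from compound 2 to compound 4 (within the scatter) therefore stays within the scatter. For compound 4 the expected value is 81%, with an estimated range from 66% to 92%.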

Compound 4, percent growth inhibition at one concentration: 29.1%
Compound 4: middle estimate off by 51.9 percentage points, on the high side, outside the stated range (below it).
By their numbers in this assay, from the lowest: compound 3; then compound 4; then compounds 1 and 2 (each within the scatter of the next).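

Swapping the group on the amide-type nitrogen, with nothing else altered in the shared core, gives a number 56.1 percentage points lower from compound 2 to compound 4 (beyond the scatter) in this assay, and bromo in place of hydroxy on an aromatic carbon gives a number 51.6 percentage points lower from compound 1 to compound 4 (beyond the scatter). The group at this position can therefore decide much of the growth inhibition, even though the earlier change here, a number 4.5 percentage points higher from compound 1 to compound 2 (within the scatter), had suggested that the position tolerated change. Nothing shown here accounts for the loss.

Compound 2 and compound 4 differ in both the halogen and its ring position, so that step alone cannot separate the two changes, while compound 1 and compound 4 both carry their group at ring position 3 and differ only in hydroxy against bromo. The compounds shown leave open whether 2-bromophenyl or 3-fluorophenyl would stay close to compound 2 or fall towards compound 4, and how a 3-chlorophenyl or 3-aminophenyl group would behave at this position.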